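The compounds below may be only part of what the source reports. "The series", "measured", "known", "first", "only" and "open" are said of these compounds alone.

Compound 1 `CNCc1cn(S(=O)(=O)c2ccco2)c(-c2cccnc2F)c1F` is the point of departure. Among the measured compounds shown here, in a functional assay on the whole organism (strain Jcl:Sprague-Dawley) for inhibition, with Rattus norvegicus as the target, with stated times of 3 min and 3 h, at a dose of 1 mg/kg by the intravenous route (on this read-out higher numbers stand for more inhibition at the one dose given (going by the name of the read-out) and lower numbers for less inhibition), compound 1 gives 75%, the lowest of the three numbers measured so far. Two close relatives differ from it only in the group carried on the sulfonyl sulfur: compound 2 `CNCc1cn(S(=O)(=O)c2ccoc2)c(-c2cccnc2F)c1F` gives 95%, and compound 3 `CNCc1cn(S(=O)(=O)c2ccc(OC)cn2)c(-c2cccnc2F)c1F` gives 95%. Both steps, a number 20 percentage points higher from compound 1 to compound 2 (beyond the scatter) and a number 20 percentage points higher from compound 1 to compound 3 (beyond the scatter), are rises beyond the scatter, whereas no change at the digits printed from compound 2 to compound 3 (within the scatter). Compound 4 `CNCc1cn(S(=O)(=O)c2ccc(F)cn2)c(-c2cccnc2F)c1F` has not been measured yet; it alters compound 1 at the same place: 5-fluoropyridin-2-yl in place of furan-2-yl on a sulfonyl sulfur. Since compound 3 also carries a six-membered aromatic ring with one hetero atom on that sulfur and gives 95%, a comparable rise is expected, a number 15 percentage points higher from compound 1 to compound 4 (beyond the scatter). Compound 4 is therefore estimated at 90%, most likely between 75% and 100%.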

Compound 4, a percentage reported as inhibition, in the whole organism at one dose (the size of the read-out at that dose, not a potency): 87%
For compound 4 the middle estimate is 3 percentage points above the measured one; low and high end bracket the measured number.
By their numbers in this assay, from the lowest: compound 1; then compounds 4, 2 and 3 (each within the scatter of the next).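

In this assay, 5-fluoropyridin-2-yl in place of furan-2-yl gives a number 12 percentage points higher from compound 1 to compound 4 (beyond the scatter), so the gain at the sulfonyl sulfur does not depend on the methoxy group of compound 3. Fluoro in place of methoxy gives a number 8 percentage points lower from compound 3 to compound 4 (within the scatter), and 5-fluoropyridin-2-yl in place of furan-3-yl gives a number 8 percentage points lower from compound 2 to compound 4 (within the scatter), so this read-out does not separate these three groups. Nothing available explains these results.

From the compounds shown here alone, whether a plain phenyl ring, or a pyridin-2-yl ring carrying an amine or a carboxylic acid, would keep the inhibition remains open. So does whether compounds 2, 3 and 4 would separate at lower doses.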